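Pyridinyl for Phenyl on an Oxadiazole Tail

A few compounds are considered here, and "the series" means these few. Any claim that something is new, unique, unknown or untested is made for them only; others in the source may bear on it.

Measured compounds:
- compound 1, `O=C1NC(=O)/C(=C/c2ccc(OCc3csc(-c4ccccc4)n3)cc2)S1`: 20.4%
- compound 2, `O=C1NC(=O)/C(=C/c2ccc(OCCSc3nnc(-c4ccccc4)o3)cc2)S1`: 14.6%

Both compounds share a thiazolidinedione core joined through a double bond to a phenyl ether, and both were tested in a functional assay on the whole organism (plasma, strain Wistar) with Rattus norvegicus as the target, with a stated time of 15 days, at a dose of 10 mg/kg by the oral route; a lower number here means a weaker effect, a higher number a stronger effect of the compound at the dose given. In this assay compound 1 gives 20.4%, and compound 2 gives 14.6%. The two values lie within the usual scatter of each other, so neither compound can be called the stronger on this evidence; compound 2 simply carries the smaller of the two numbers.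

Compound 3, `O=C1NC(=O)/C(=C/c2ccc(OCCSc3nnc(-c4cccnc4)o3)cc2)S1`, is not yet measured. It differs from compound 2 in one place: pyridin-3-yl in place of phenyl on an aromatic carbon. Among the compounds with values here, no step between measured compounds tells how such a change plays out here, so the expectation rests on the shared core alone. The step of a number 0.4 percentage points higher from compound 2 to compound 3 (within the scatter) is expected to stay within the scatter, in no clear direction. Compound 3 is therefore estimated at 15%, with a range from 5% to 30%.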

Compound 3, a percentage reported as activity, at one dose (the size of the read-out at that dose, not a potency): 33.2%
Beside the measured number, compound 3's estimate is 18.2 percentage points below it, outside the stated range (above it).
By their numbers in this assay, from the lowest: compounds 2 and 1 (each within the scatter of the next); then compound 3.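

In this assay, within the data shown here, putting pyridin-3-yl in place of phenyl on the aromatic carbon of the five-membered ring gives a number 18.6 percentage points higher from compound 2 to compound 3 (beyond the scatter), the only step in this set and one that lies beyond the scatter. So this position is not indifferent to the change: swapping one ring carbon for nitrogen leaves the heavy-atom count unchanged and adds one hydrogen-bond acceptor, yet the read-out at this dose still moves upward. Nothing shown speaks to the reason for this rise.

Going by these compounds, whether the rise depends on where the nitrogen sits in the ring remains open, and pyridin-4-yl or pyridin-2-yl on the same carbon would test that. On these data alone, it is also open whether pyridin-3-yl would give a similar step in place of the phenyl of compound 1.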